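Changing the benzyl substituents on a shared nucleoside core

The source may hold more compounds than are shown below. What is called first, only, known or untested is meant among the compounds shown, and "the series" means these compounds.

Measured compounds:
Compound 1, `OC[C@H]1O[C@@H](n2cnc3c(NCc4cccc(F)c4)ncnc32)[C@H](O)[C@@H]1O`, gives 15300 nM in a functional assay on MCF cells (Homo sapiens) for antiproliferative activity, with a stated time of 72 h; on this read-out lower numbers stand for stronger inhibition and higher numbers for weaker inhibition.
Compound 2, `COc1cc(CNc2ncnc3c2ncn3[C@@H]2O[C@H](CO)[C@@H](O)[C@H]2O)cc(OC)c1`, is reported only as a limit of this assay, > 166000 nM.
Compound 3, `OC[C@H]1O[C@@H](n2cnc3c(NCc4ccc(F)cc4F)ncnc32)[C@H](O)[C@@H]1O`, likewise reaches only the limit of this assay, > 166000 nM.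

Going by the values given here, compound 1 therefore holds the only actual number in this assay; the other two results sit at a limit, as the limit of > 166000 nM in this assay, at which 2 of the 3 values shown sit, records. The step to compound 4, `OC[C@H]1O[C@@H](n2cnc3c(NCc4ccc(F)c(Cl)c4)ncnc32)[C@H](O)[C@@H]1O`, is 3-chloro-4-fluorophenyl in place of 3-fluorophenyl on a saturated chain carbon bound to a nitrogen on an aromatic ring. Two measured steps change the same phenyl group on the same saturated chain carbon: an at least 10-fold higher number from compound 1 to compound 2 (1.03 log units; beyond the scatter) and an at least 10-fold higher number from compound 1 to compound 3 (1.03 log units; beyond the scatter). Both replacements of the 3-fluorophenyl weakened inhibition past the limit, and the step from compound 2 to compound 3 itself cannot be read, a step that the two limits leave unreadable from compound 2 to compound 3. The move to 3-chloro-4-fluorophenyl is a smaller change than either of those, so a weaker inhibition than compound 1 is expected, though not necessarily out to the limit. Compound 4 is expected at 45000 nM, within 12000 nM to 170000 nM. That estimate means a 2.9-fold higher number from compound 1 to compound 4 (0.47 log units; beyond the scatter).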

Compound 4, half-maximal inhibitory concentration: > 166000 nM
Compound 4: only a limit was reported; the forecaster's own chance of this, stated with the estimate: 40%; middle value at least 3.6-fold (0.56 log units) from the limit.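

Even the 3-chloro-4-fluorophenyl group, which still carries a fluorine on the ring, gives an at least 10-fold higher number from compound 1 to compound 4 (1.03 log units; beyond the scatter). Compound 4 is reported only as a limit of this assay, > 166000 nM, so its steps to compound 2 and compound 3 cannot be read. All three replacements of the 3-fluorophenyl on this saturated chain carbon, whether they carry methoxy groups, two fluorines, or a chlorine and a fluorine, now end at the same ceiling, and compound 1 alone keeps a real number: the limit of > 166000 nM in this assay, at which 3 of the 4 values shown sit.

As far as these compounds go, how far compound 2, compound 3 and compound 4 actually lie beyond that limit stays unknown, so they cannot be ranked against one another. Also open, from the compounds shown here alone, is whether any group here can beat the 3-fluorophenyl, for example an unsubstituted phenyl, a 3-chlorophenyl or a 3-aminophenyl.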